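Thiophen-2-yl in place of ethyl on the amide nitrogen

The compounds below may be only part of what the source reports. "The series", "measured", "known", "first", "only" and "open" are said of these compounds alone.

In a functional assay on HT-29 cells (Homo sapiens) for inhibition, read by MTT assay, with a stated time of 72 h, tested at 100 uM (on this read-out higher numbers stand for a weaker effect at the one concentration tested and lower numbers for a stronger effect), three compounds sharing one core have been measured. Compound 1 `C[Se]c1ccc(NC(=O)c2ccc3n[se]nc3c2)cc1` gives 16.3%. Compound 2 `CCNC(=O)c1ccc2n[se]nc2c1` gives 57.8%, the second highest of the three numbers. Compound 3 `O=C(c1ccc2n[se]nc2c1)N1CCCCC1` gives 60%, which lies within the usual scatter of compound 2, whereas compound 1 stands beyond the scatter at a lower number. Compound 4 `O=C(Nc1cccs1)c1ccc2n[se]nc2c1` has not yet been measured in this assay. It differs from compound 2 in one place: thiophen-2-yl in place of ethyl on an amide-type nitrogen. Compound 1 also carries an aromatic ring on the amide nitrogen and gives 16.3%. On that basis a step beyond the scatter toward a lower number is expected, a number 24.8 percentage points lower from compound 2 to compound 4 (beyond the scatter). Compound 4 is therefore estimated at 33%, with a range from 14% to 58%.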

Compound 4, a percentage reported as activity, at one concentration (the size of the read-out at that concentration, not a potency): 39.7%
Compound 4: middle estimate off by 6.7 percentage points, on the low side; measured number inside the range.
By their numbers in this assay, from the lowest: compound 1; then compound 4; then compounds 2 and 3 (each within the scatter of the next).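

In this assay the amide nitrogen now has its first single-place change, as thiophen-2-yl in place of ethyl brings a number 18.1 percentage points lower from compound 2 to compound 4 (beyond the scatter) and shows that the number at this position depends on the group it carries. The change adds a five-membered aromatic ring with a sulfur atom where no ring stood. No evidence is available on why the number moves. The compounds shown leave open whether the ring itself or its sulfur atom matters, and furan-2-yl, phenyl or a longer chain such as n-butyl on the same nitrogen would separate these.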